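Swapping the ureidomethyl for piperidin-4-yl

The compounds below may be only part of what the source reports. "The series", "measured", "known", "first", "only" and "open" are said of these compounds alone.

Measured compounds:
Compound 1, `NCCCCN(C[C@H]1Cc2nccnc2CN1)[C@H]1CCCc2cccnc21`: 84%
Compound 2, `NCCCCN(C[C@@H]1Cc2nccnc2CN1)[C@H]1CCCc2cccnc21`: 87%
Compound 3, `NC(=O)NCCCCN(C[C@H]1Cc2ncccc2CN1)[C@H]1CCCc2cccnc21`: 91%

In an ADME assay on microsomes from liver (Homo sapiens) for metabolic stability, using NADPH, with a stated time of 10 min (on this read-out higher numbers stand for a more stable compound and lower numbers for a less stable compound), compound 3 gives the highest of the three numbers, though its gaps to compound 2 and to compound 1 both lie within the scatter. Among the measured compounds shown here, the one step between compounds that differ in a single place is a number 3 percentage points higher from compound 1 to compound 2 (within the scatter); it rests on the fact that compounds 1 and 2 differ only in the configuration as drawn and says nothing about a change of substituent on the chain.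

Compound 4, `c1cnc2c(c1)CN[C@@H](CN(CCCC1CCNCC1)[C@H]1CCCc3cccnc31)C2`, has not been measured. It differs from compound 3 in this way: piperidin-4-yl in place of ureidomethyl on a saturated chain carbon, three bonds along the chain from an amine nitrogen. For the measured compounds named here, no measured step bears on such a change, so nothing here points to a move beyond the scatter in either direction in this assay.

Compound 4 is therefore expected to give about 85% in this assay, between 68% and 96%, which is an expected step of a number 6 percentage points lower from compound 3 to compound 4 (within the scatter).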

Compound 4, percent of the compound remaining: 100%
For compound 4 the middle estimate is 15 percentage points below the measured one, and the stated range ends below it.
By their numbers in this assay, from the lowest: compounds 1, 2, 3 and 4 (each within the scatter of the next, the first and the last beyond it).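

In this assay, exchanging ureidomethyl for piperidin-4-yl on a saturated chain carbon, three bonds along the chain from an amine nitrogen, gives a number 9 percentage points higher from compound 3 to compound 4 (within the scatter). This is the first step shown for a change of substituent at this place, the earlier step having concerned only the configuration as drawn, and it shows that a chain ending in a six-membered non-aromatic ring gives a number within the scatter of the number for the chain ending in the urea. Nothing given here explains this step.

The compounds shown leave open how a carboxylic acid or a morpholine at this place on the chain would read in this assay. They also leave open whether a shorter or longer chain carrying piperidin-4-yl would stay within the scatter of compound 4.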